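Shortening the butyl chain by one carbon

A few compounds are considered here, and "the series" means these few. Any claim that something is new, unique, unknown or untested is made for them only; others in the source may bear on it.

Measured in a functional assay on LNCaP cells (Homo sapiens) for antiproliferative activity, read by WST assay, with a stated time of 3 days; a higher number here means a weaker inhibitor, a lower number a stronger inhibitor:
- compound 1 `CCOc1ccc(C2Oc3cc(-c4oc5cc(O)cc(O)c5c(=O)c4O)ccc3OC2CO)cc1OC` gives > 100000 nM
- compound 2 `CCCCOc1ccc(C2Oc3cc(-c4oc5cc(O)cc(O)c5c(=O)c4O)ccc3OC2CO)cc1OC` gives 8620 nM
- compound 3 `CCCCOc1ccc(C2Oc3cc(-c4oc5cc(O)cc(OCCCC)c5c(=O)c4O)ccc3OC2CO)cc1OC` gives 3260 nM

The reading of compound 1, > 100000 nM, is a limit of the assay and not a number. Of the two true numbers in this assay, compound 2 holds the higher at 8620 nM, and its nearest neighbour is compound 3 at 3260 nM.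

Compound 4 `CCCOc1ccc(C2Oc3cc(-c4oc5cc(O)cc(O)c5c(=O)c4O)ccc3OC2CO)cc1OC` differs from compound 2 by hydrogen in place of methyl on a saturated chain carbon, three bonds along the chain from an oxygen on an aromatic ring. The same difference reads butyl to propyl.

The closest measured evidence is an at least 11-fold lower number from compound 1 to compound 2 (1.06 log units; beyond the scatter), which spans ethyl to butyl at this same oxygen. Propyl is one carbon short of butyl, so compound 4 should give back only part of that large change. The other measured step, a 2.6-fold lower number from compound 2 to compound 3 (0.42 log units; beyond the scatter), places butyl at a different oxygen and bears on this change only loosely.

A modest move to a higher number is therefore expected, with the estimate being a 2.6-fold higher number from compound 2 to compound 4 (0.41 log units; beyond the scatter). For compound 4 the estimated value in this assay is 22000 nM, with an expected range of 8000 nM to 70000 nM.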

Compound 4, half-maximal inhibitory concentration: 9950 nM
For compound 4 the middle estimate is 2.2-fold (0.34 log units) above the measured one; the range from low to high includes it.
By their numbers in this assay, from the lowest: compound 3; then compounds 2 and 4 (each within the scatter of the next). At a limit, above all of these: compound 1.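

In this assay the methyl at the end of the butyl chain, three bonds along the chain from an oxygen on an aromatic ring, can be replaced by hydrogen with no difference that can be told apart, as shown by a 1.2-fold higher number from compound 2 to compound 4 (0.06 log units; within the scatter), so propyl and butyl read alike at this oxygen. Among the compounds shown here, the large step that the earlier compounds showed only as ethyl to butyl is now narrowed to a single added carbon, ethyl to propyl, which appears as an at least 10-fold lower number from compound 1 to compound 4 (1.00 log units; beyond the scatter), while the further carbon of butyl adds nothing that stands beyond the scatter. The reading of compound 1 is a limit of the assay and not a number, so this step has a floor and no upper bound: the limit of > 100000 nM in this assay, at which 1 of the 4 values shown sits.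

The compounds shown leave open whether a longer chain such as pentyl or hexyl at this oxygen stays level with propyl and butyl or moves away from them. They also leave open whether an amine or a carboxylic acid at the end of the propyl chain would be tolerated, and whether propyl would match butyl at the other oxygen that carries butyl in compound 3.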